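Extending the Side-Chain Unsaturation of Compound 1

A few compounds are considered here, and "the series" means these few. Any claim that something is new, unique, unknown or untested is made for them only; others in the source may bear on it.

Compound 1 `CCCC/C=C\CCCCCCCCCc1cc(=O)c2c(O)cc(O)c(C)c2o1` — 17500 nM
Compound 2 `CCCCC/C=C\C/C=C\CCCCCCCC1(O)CC(=O)c2c(O)cc(OCOC)cc2O1` — > 84100 nM
Compound 3 `CCCCC/C=C\C/C=C\CCCCCCCc1cc(=O)c2c(O)cc(OCOC)cc2o1` — > 67200 nM

For the measured compounds named here, in a functional assay on MCF7 cells (Homo sapiens) for antiproliferative activity, read by MTT assay (on this read-out higher numbers stand for weaker inhibition and lower numbers for stronger inhibition), compound 1 gives 17500 nM, the only number among the three values shown. Compound 2 reaches only a limit of this assay, > 84100 nM. Compound 3 likewise stops at a limit, > 67200 nM. One value sits at the limit of > 67200 nM in this assay, at which 1 of the 3 values shown sits, and one at the limit of > 84100 nM in this assay, at which 1 of the 3 values shown sits, so compound 1 alone offers a starting point.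

Compound 4 `CC/C=C\C/C=C\C/C=C\CCCCCCCc1cc(=O)c2c(O)cc(O)c(C)c2o1` keeps the core of compound 1 and alters only the side chain: a group of 10 heavy atoms (10 carbon; no ring) in place of a group of 8 heavy atoms (8 carbon; no ring), on a saturated chain carbon, seven bonds along the chain from an aromatic carbon. Going by the values given here, no measured pair differs in this one place, so no step of known size guides the change. The expectation is a step no larger than the usual scatter, if anything toward weaker inhibition. Compound 4 is therefore estimated at 22000 nM, between 8000 nM and 60000 nM, a step of a 1.3-fold higher number from compound 1 to compound 4 (0.10 log units; within the scatter).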

Compound 4, half-maximal inhibitory concentration: 17500 nM
For compound 4 the middle estimate is 1.3-fold (0.10 log units) above the measured one, and the stated range covers the measured number.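

In this assay, replacing oct-3-en-1-yl with a group of 10 heavy atoms and 3 double bonds outside aromatic rings gives no change at the digits printed from compound 1 to compound 4 (within the scatter). For the compounds shown here, this is the first step that can be read at this place, on a saturated chain carbon, seven bonds along the chain from an aromatic carbon, and it shows that this change of length and unsaturation leaves the antiproliferative reading where it was. Nothing measured here bears on why the number holds. From the compounds shown here alone, whether an amine or a carboxylic acid on this chain, or a much shorter chain, would move the number remains open.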